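Thiophene Replaces Tolyl on a Triazole-Linked Nucleoside

The compounds below may be only part of what the source reports. "The series", "measured", "known", "first", "only" and "open" are said of these compounds alone.

Going by the values given here, compound 2 `CCS[C@@H]1[C@H](SCC)[C@@H](Cn2cc(-c3ccc(C)cc3)nn2)O[C@H]1n1cc(C)c(=O)[nH]c1=O` gives the highest of the two numbers so far in a functional assay on A549 cells (Homo sapiens) for cytotoxicity, read by MTT assay, with a stated time of 72 h (on this read-out higher numbers stand for an effect only at larger amounts of compound and lower numbers for an effect already at smaller amounts), namely 12300 nM; its only comparator, compound 1 `CCS[C@@H]1[C@H](SCC)[C@@H](Cn2cc(-c3ccccc3C(F)(F)F)nn2)O[C@H]1n1cc(C)c(=O)[nH]c1=O`, gives 7230 nM, and the step of a 1.7-fold higher number from compound 1 to compound 2 (0.23 log units; within the scatter) lies within the scatter. Compound 3 `CCS[C@@H]1[C@H](SCC)[C@@H](Cn2cc(-c3cccs3)nn2)O[C@H]1n1cc(C)c(=O)[nH]c1=O` carries thiophen-2-yl in place of 4-methylphenyl on an aromatic carbon. Among the compounds with values here, no measured step exchanges a phenyl ring for a thiophene; the one ring-for-ring swap seen, a 1.7-fold higher number from compound 1 to compound 2 (0.23 log units; within the scatter), stayed within the scatter. The expected step of a 1.2-fold lower number from compound 2 to compound 3 (0.09 log units; within the scatter) is therefore small, within the scatter, with no direction claimed. Compound 3 is estimated at 10000 nM, with a range from 4000 nM to 25000 nM.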

Compound 3, half-maximal effective concentration: 37300 nM
Estimate against measurement, compound 3: 3.7-fold (0.57 log units) below; measured number outside the range, above it.
By their numbers in this assay, from the lowest: compounds 1 and 2 (each within the scatter of the next); then compound 3.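

In this assay, the group on this aromatic carbon moves the number beyond the scatter, with a 3.0-fold higher number from compound 2 to compound 3 (0.48 log units; beyond the scatter) and a 5.2-fold higher number from compound 1 to compound 3 (0.71 log units; beyond the scatter) as the result. The two six-membered aromatic rings, 4-methylphenyl and 2-(trifluoromethyl)phenyl, remain within the scatter of each other, so only thiophen-2-yl, a five-membered aromatic ring with 1 hetero atom, stands apart from them. Nothing at hand accounts for this shift.

Open, from the compounds shown here alone, is whether the number follows the ring size or the sulfur. Also open, going by these compounds, is whether a pyridine ring, or a phenyl ring bearing an amine or a carboxylic acid, would move it in either direction.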